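Swapping phenyl for pyridin-2-yl on a shared core

This account rests on a few compounds, and the source may have more. Where it says the series, first, only, none or still open, it means among the compounds named here.

Of the compounds shown here, three sharing one core have been tested in a functional assay on HepG2 cells (Homo sapiens) for cytotoxicity, read by MTT assay, with a stated time of 48 h; a lower number here means a stronger inhibitor, a higher number a weaker inhibitor. Compound 1 `O=C1/C(=C\c2ccccc2)S/C(=N/c2ccccc2)N1Cc1ccncc1` gives 25200 nM. Compound 2 `O=C1/C(=C\c2ccc(O)cc2)S/C(=N/c2ccccc2)N1Cc1ccncc1` gives 11800 nM, and compound 3 `O=C1/C(=C\c2ccc(Cl)cc2)S/C(=N/c2ccccc2)N1Cc1ccncc1` gives 28800 nM. Among these three numbers compound 1 stands second highest; compound 3 sits nearest to it, and compound 2 lies furthest away, with a lower number.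

The two changes seen so far both touch the ring carried on the double-bonded chain carbon. Putting hydroxy in place of hydrogen there gave a 2.1-fold lower number from compound 1 to compound 2 (0.33 log units; beyond the scatter), a modest shift beyond the scatter, while putting chloro in place of hydrogen gave a 1.1-fold higher number from compound 1 to compound 3 (0.06 log units; within the scatter), which is within the scatter.

Compound 4 `O=C1/C(=C\c2ccccn2)S/C(=N/c2ccccc2)N1Cc1ccncc1` has not yet been measured in this assay. It differs from compound 1 by pyridin-2-yl in place of phenyl on a double-bonded chain carbon bound to a double-bonded ring carbon. No earlier step exchanges this ring itself, so the expectation rests on the observation that both changes made on it so far moved the number by little or not at all, as shown by a 2.1-fold lower number from compound 1 to compound 2 (0.33 log units; beyond the scatter) and a 1.1-fold higher number from compound 1 to compound 3 (0.06 log units; within the scatter). Compound 4 is therefore expected to land close to compound 1, with an estimated step of a 1.1-fold lower number from compound 1 to compound 4 (0.06 log units; within the scatter). The estimated value for compound 4 is 22000 nM, with a range from 10000 nM to 48000 nM.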

Compound 4, half-maximal inhibitory concentration: 31000 nM
Compound 4: middle estimate off by 1.4-fold (0.15 log units), on the low side, within the range that was stated.
By their numbers in this assay, from the lowest: compound 2; then compounds 1, 3 and 4 (each within the scatter of the next).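

In this assay, the ring at this position can be exchanged whole, not just decorated: pyridin-2-yl in place of phenyl, which brings a ring nitrogen and one hydrogen-bond acceptor, gives a 1.2-fold higher number from compound 1 to compound 4 (0.09 log units; within the scatter) and so cannot be told apart from compound 1. The same holds against the chlorinated ring, with a 1.1-fold higher number from compound 3 to compound 4 (0.03 log units; within the scatter) for the exchange of 4-chlorophenyl for pyridin-2-yl. Compound 2 therefore remains the only one of the four set apart from all the others, with a 2.6-fold higher number from compound 2 to compound 4 (0.42 log units; beyond the scatter) as a modest gap, and nothing measured here gives a reason for either the match or that gap.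

Pyridin-3-yl or pyridin-4-yl on this carbon would show whether the place of the ring nitrogen matters, as the present result covers pyridin-2-yl alone. Methoxy or an amine in place of the hydroxy of compound 2 would show whether its lower number belongs to hydroxy alone or extends to other groups at that spot on the ring.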